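This account rests on a few compounds, and the source may have more. Where it says the series, first, only, none or still open, it means among the compounds named here.

Compound 2 `Cc1nc(S(C)(=O)=O)ccc1Oc1ncnc(OC2CCN(C(=O)OC3COC3)CC2)c1F` gives 66% in a functional assay on isolated protein for inhibition of Glucose-dependent insulinotropic receptor (Rattus norvegicus), read by HTRF and cAMP accumulation (a lower number here means a smaller maximal response, a higher number a larger maximal response), the lowest of the three measured numbers. Compound 1 `Cc1nc(S(C)(=O)=O)ccc1Oc1ncnc(OC2CCN(C(=O)OC3CCC3)CC2)c1F` gives 81% in this assay, and compound 3 `Cc1nc(S(C)(=O)=O)ccc1Oc1ncnc(OC2CCN(C(=O)c3nc(C(C)(C)F)no3)CC2)c1F` gives 84%. Compound 4 `CCc1cnc(C(=O)N2CCC(Oc3ncnc(Oc4ccc(S(C)(=O)=O)nc4C)c3F)CC2)nc1` has not yet been measured; it differs from compound 2 by 5-ethylpyrimidin-2-yl in place of (oxetan-3-yl)oxy on a carbonyl carbon. The step most alike is a number 18 percentage points higher from compound 2 to compound 3 (beyond the scatter), where an aromatic ring with hetero atoms also replaced a four-membered non-aromatic ring on the carbonyl carbon. The two four-membered rings themselves differ, as a number 15 percentage points lower from compound 1 to compound 2 (beyond the scatter) shows, while a number 3 percentage points higher from compound 1 to compound 3 (within the scatter) is small. A rise beyond the scatter is therefore expected, a number 16 percentage points higher from compound 2 to compound 4 (beyond the scatter). For compound 4 the estimate in this assay is 82%, with a range from 70% to 94%.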

Compound 4, largest response reached (reported as efficacy), in percent of the reference or control that the assay uses: 80%
For compound 4 the middle estimate is 2 percentage points above the measured one, within the range that was stated.
By their numbers in this assay, from the lowest: compound 2; then compounds 4, 1 and 3 (each within the scatter of the next).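

With 5-ethylpyrimidin-2-yl on the carbonyl carbon, this assay shows a number 14 percentage points higher from compound 2 to compound 4 (beyond the scatter), so a six-membered aromatic ring also gives a rise over (oxetan-3-yl)oxy. Both a number 4 percentage points lower from compound 3 to compound 4 (within the scatter) and a number 1 percentage points lower from compound 1 to compound 4 (within the scatter) are within the scatter, so this position does not separate 5-ethylpyrimidin-2-yl from cyclobutyloxy or the five-membered aromatic ring in these compounds. Nothing available explains why (oxetan-3-yl)oxy gives the lowest number. Whether the ethyl contributes remains open, since no unsubstituted pyrimidin-2-yl is shown. From the compounds shown here alone, how an amine, such as dimethylamino, would behave on this carbonyl carbon also remains open.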